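The source may report more compounds than this note shows. Statements on the series, on what has been measured and on what is new or still open speak of the compounds shown alone.

Working notes on the series. The shared core carries an acrylamide side chain, and the amide nitrogen is the point of variation. Among the compounds with values here, compound 1 `COc1ccc2c(=O)c(/C=C/C(=O)Nc3ccccc3)coc2c1` is the only member with a numerical result so far: in a functional assay (QGY7701 cells, Homo sapiens) for inhibition, read by MTT assay, with a stated time of 48 h (a lower number here means a stronger inhibitor, a higher number a weaker inhibitor), compound 1 gives 14000 nM, a weak inhibition. Compound 2 `O=C(/C=C/c1coc2cc(O)ccc2c1=O)NCc1ccc(F)cc1` is the other measured member. Compound 2 reaches only > 100000 nM in this assay, which is a limit of the assay and not a number; this is the limit of > 100000 nM in this assay, at which 1 of the 2 values shown sits. Within the data shown here, compound 1 therefore stands as the sole defined value, with nothing in the set to rank it against beyond that limit.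

Compound 3 `COc1ccc(CNC(=O)/C=C/c2coc3cc(OC)ccc3c2=O)cc1` is not yet measured. It differs from compound 1 by 4-methoxybenzyl in place of phenyl on an amide-type nitrogen. Among the measured compounds shown here, no step between two measured compounds is available to calibrate this change. The expected move in this assay is towards weaker inhibition, estimated as a 2.5-fold higher number from compound 1 to compound 3 (0.40 log units; beyond the scatter), a shift that is expected to exceed the usual scatter though not by much. For compound 3 the estimate in this assay is 35000 nM, with a range from 12000 nM to 100000 nM, and a real chance that only a limit is reported.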

Compound 3, half-maximal inhibitory concentration: 15700 nM
For compound 3 the middle estimate is 2.2-fold (0.35 log units) above the measured one, and the stated range covers the measured number.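

The amide nitrogen now has its first readable step: in this assay the change gives a 1.1-fold higher number from compound 1 to compound 3 (0.05 log units; within the scatter) and so does not separate 4-methoxybenzyl from phenyl at this position. A larger group with one more hydrogen-bond acceptor by the count of the two substituents therefore leaves the result within the scatter on the methoxy-bearing core, and compound 3 joins compound 1 as a second defined value in the weak range rather than as a limit. No measurement shown gives a reason for this lack of separation, and a single step sets no trend for the position.

Compound 2 differs from both measured neighbours in more than one place, so it gives no readable step and the contributions of its core hydroxyl and its 4-fluorobenzyl group stay unseparated. Also open, from the compounds shown here alone, is whether anything stronger can come from this nitrogen, for example with a dimethylamino group on a two-carbon chain, a carboxylic acid on the aromatic ring, or a longer chain such as phenethyl.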